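Swapping the ester side chain on compound 3

The compounds below may be only part of what the source reports. "The series", "measured", "known", "first", "only" and "open" are said of these compounds alone.

Measured so far:
compound 1 `CC1=NC(C)=C(C(=O)OCCCN2C(=O)c3ccccc3S2(=O)=O)C(c2cccc([N+](=O)[O-])c2)/C1=C(\O)OCC1CCCO1`: 10.5 nM
compound 2 `CO/C(O)=C1\C(C)=NC(C)=C(C(=O)OCCCN2C(=O)c3ccccc3S2(=O)=O)C1c1ccccc1[N+](=O)[O-]`: 1.5 nM
compound 3 `CC1=NC(C)=C(C(=O)OCCCN2C(=O)c3ccccc3S2(=O)=O)C(c2ccccc2[N+](=O)[O-])/C1=C(\O)OC(C)C`: 1.2 nM

In a functional assay (aorta) with Oryctolagus cuniculus as the target (on this read-out higher numbers stand for weaker inhibition and lower numbers for stronger inhibition), compound 3 gives 1.2 nM, the lowest of the three numbers, though compound 2 sits within the scatter of it, so the two cannot be ranked; compound 1 stands clearly higher. Compound 4 `CC1=NC(C)=C(C(=O)OCCCN2C(=O)c3ccccc3S2(=O)=O)C(c2ccccc2[N+](=O)[O-])/C1=C(\O)OCC1CCCO1` has not been measured; it arises from compound 3 by (oxolan-2-yl)methyl in place of isopropyl on an oxygen on an unsaturated carbon. Going by the values given here, the only measured step that touches this position is a 1.3-fold lower number from compound 2 to compound 3 (0.10 log units; within the scatter), a change of the same ester group that left the number essentially where it was. Compound 1 also carries the (oxolan-2-yl)methyl ester, but it differs from compound 4 in another part of the structure as well, so its value can only be noted, not used as a step. On this basis the expected change from compound 3 to compound 4 is a 1.7-fold higher number from compound 3 to compound 4 (0.22 log units; within the scatter), small and not clearly beyond the scatter. Compound 4 is therefore estimated at 2 nM, with a likely range from 0.7 nM to 6 nM.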

Compound 4, half-maximal inhibitory concentration: 6.8 nM
The estimate for compound 4 lay 3.4-fold (0.53 log units) below the measured number; measured number outside the range, above it.
By their numbers in this assay, from the lowest: compounds 3 and 2 (each within the scatter of the next); then compounds 4 and 1 (each within the scatter of the next).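

In this assay, going by these compounds alone, this ester position proves less tolerant than the earlier compounds suggested: methyl and isopropyl could not be told apart, whereas (oxolan-2-yl)methyl in place of isopropyl gives a 5.7-fold higher number from compound 3 to compound 4 (0.75 log units; beyond the scatter). Within the data shown here, measured against the methyl ester, the same group gives a 4.5-fold higher number from compound 2 to compound 4 (0.66 log units; beyond the scatter), so with 2-nitrophenyl on the core this is the first change at the position to pass beyond the scatter. With the (oxolan-2-yl)methyl ester held fixed, 2-nitrophenyl in place of 3-nitrophenyl gives only a 1.5-fold lower number from compound 1 to compound 4 (0.19 log units; within the scatter), so those two compounds cannot be ranked.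

No independent evidence bears on what lies behind the step at the ester. The compounds shown leave open whether the higher number goes with the ring itself or simply with a larger group, a question that an open-chain 2-methoxyethyl ester and a plain butyl ester could help to separate.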